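Swapping Trifluoromethyl for Chloro in a Cytotoxicity Test

The source may report more compounds than this note shows. Statements on the series, on what has been measured and on what is new or still open speak of the compounds shown alone.

Values so far in an ADME assay on L02 cells (Homo sapiens) for cytotoxicity, read by MTT assay, with a stated time of 24 h; a higher number here means a weaker inhibitor, a lower number a stronger inhibitor
- compound 1 `O=C1/C(=C/c2ccncc2)CN(S(=O)(=O)c2ccc(Cl)cc2)C/C1=C\c1ccccc1F` gives 15000 nM
- compound 2 `O=C1/C(=C/c2ccncc2)CN(S(=O)(=O)c2ccc(C(F)(F)F)cc2)C/C1=C\c1ccccc1C(F)(F)F` gives 13800 nM

Within the data shown here, only two compounds have been measured, and compound 2 at 13800 nM lies within the usual scatter of compound 1 at 15000 nM in this assay. Repeat measurements of a single compound could differ this much, so the two cannot be ranked.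

Compound 3 `O=C1/C(=C/c2ccncc2)CN(S(=O)(=O)c2ccc(Cl)cc2)C/C1=C\c1ccccc1C(F)(F)F` has not yet been measured. Going from compound 2 to compound 3, a 4-(trifluoromethyl)phenyl becomes a 4-chlorophenyl, with chloro in place of trifluoromethyl on an aromatic carbon, para to a large group (chloro in place of trifluoromethyl on an aromatic carbon). This chloro also appears on compound 1, so compound 3 shares a feature with each measured compound.

Among the measured compounds shown here, no measured pair isolates this single change, so the evidence is thin. For the measured compounds named here, still, with compound 1 at 15000 nM and compound 2 at 13800 nM as the only guides, no shift beyond the scatter is expected. The expected step of a 1.1-fold higher number from compound 2 to compound 3 (0.02 log units; within the scatter) is small and has no firm direction. For compound 3 the estimated value is 14500 nM with an expected range from 9000 nM to 23000 nM until a measurement is available.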

Compound 3, half-maximal inhibitory concentration: 14900 nM
Beside the measured number, compound 3's estimate is 1.0-fold (0.01 log units) below it; low and high end bracket the measured number.
By their numbers in this assay, from the lowest: compounds 2, 3 and 1 (each within the scatter of the next).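

The earlier pair, compound 1 and compound 2, differ in two places, so neither change could be read alone; compound 3 separates them. In this assay, chloro in place of trifluoromethyl on an aromatic carbon, para to a large group, gives a 1.1-fold higher number from compound 2 to compound 3 (0.03 log units; within the scatter), and trifluoromethyl in place of fluoro on an aromatic carbon gives a 1.0-fold lower number from compound 1 to compound 3 (0.00 log units; within the scatter), so each single change on its own stays within the scatter of this test. No other measurement is at hand that would explain this result.

The compounds shown leave open whether a group of another kind in place of the chloro, such as an amine or a carboxylic acid, would move the number in this assay beyond the scatter. The same question stands for the aromatic carbon that carries fluoro in compound 1 and trifluoromethyl in compound 3, where a methoxy group or a longer chain could be compared with these two groups.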